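The compounds below may be only part of what the source reports. "The series", "measured", "known", "first", "only" and "open" are said of these compounds alone.

In an ADME assay on MDCK cells (Canis lupus familiaris) for cytotoxicity, read by MTT assay, with a stated time of 48 h (on this read-out higher numbers stand for lower toxicity in this test and lower numbers for higher toxicity in this test), compound 1 `COc1cc([C@H]2CC(C)(O)[C@@H]3CC[C@@H](C)C[C@H]3O2)ccc1O` gives 411000 nM. Compound 2 `COc1cc([C@H]2CC(C)(O)[C@@H]3CC[C@@H](C)C[C@H]3O2)cc(OC)c1O`, which carries the change (methoxy in place of hydrogen on an aromatic carbon), gives 473000 nM in this assay, so that the step of a 1.2-fold higher number from compound 1 to compound 2 (0.06 log units; within the scatter) stays within the scatter. Compound 3 `COc1ccc([C@H]2CC(C)(F)[C@@H]3CC[C@@H](C)C[C@H]3O2)cc1OC` gives 20000 nM in this assay, the lowest of the three numbers; the difference between the core of compound 3 and the core of compound 1 is not broken down here. Compound 4 `COc1cc(OC)c([C@H]2CC(C)(F)[C@@H]3CC[C@@H](C)C[C@H]3O2)cc1OC` has not yet been measured in this assay. Among the compounds with values here, compound 4 differs from compound 3 by methoxy in place of hydrogen on an aromatic carbon; this is the same kind of change as the one from compound 1 to compound 2, but the surroundings of the place differ: in compound 2 the entering methoxy sits ortho to a hydroxy group and meta to a large group, while in compound 4 it sits ortho to a large group and para to a methoxy group. Because the step of a 1.2-fold higher number from compound 1 to compound 2 (0.06 log units; within the scatter) lay within the scatter, the step from compound 3 to compound 4 is expected to be of similar size, a 1.2-fold higher number from compound 3 to compound 4 (0.08 log units; within the scatter), resting on that single earlier example. Compound 4 is thus estimated at 24000 nM in this assay, between 8000 nM and 70000 nM.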

Compound 4, half-maximal cytotoxic concentration: 78000 nM
Estimate against measurement, compound 4: 3.3-fold (0.51 log units) below; the measured number lies above the stated range.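

In this assay, methoxy in place of hydrogen on an aromatic carbon gives a 3.9-fold higher number from compound 3 to compound 4 (0.59 log units; beyond the scatter), and the same change does not bring a step of one size on the two cores: the same change on two cores in this assay, a 1.2-fold higher number (0.06 log units; within the scatter) from compound 1 to compound 2 and a 3.9-fold higher number (0.59 log units; beyond the scatter) from compound 3 to compound 4, 3.4-fold (0.53 log units) apart, beyond the scatter of two such steps In this series, then, the size of the step seen on the core of compound 1 could not simply be carried over to the core of compound 3. It does not show what sets the two steps apart, since the pairs differ both in the core and in the surroundings of the entering methoxy, and two pairs give no rule for other cores.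

The compounds shown leave open whether a methoxy ortho to a large group and para to a methoxy group on the core of compound 1 would give a step like the one on the core of compound 3. They also leave open whether an ethoxy group or an amine entering at that place would shift the number in the same way.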